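Swapping a Methyl for a Chloro on the Aromatic Ring

The compounds below may be only part of what the source reports. "The series", "measured", "known", "first", "only" and "open" are said of these compounds alone.

Of the compounds shown here, two sharing one core have been measured in an ADME assay on Vero cells (Chlorocebus sabaeus) for cytotoxicity, with a stated time of 72 h, tested at 10 ug/mL; a lower number here means a weaker effect, a higher number a stronger effect of the compound at the concentration tested. Compound 1 `O=c1[nH]nc2n(c1=O)CCN2c1ccccc1` carries an unsubstituted phenyl ring, and in this assay compound 1 gives 7%. Compound 2 `Cc1ccc(N2CCn3c2n[nH]c(=O)c3=O)cc1` differs from it by a methyl in place of hydrogen on an aromatic carbon, and in this assay compound 2 gives 0%. Among the compounds with values here, the only step recorded is a number 7 percentage points lower from compound 1 to compound 2 (within the scatter), so the two numbers stand together and neither compound can be called weaker or stronger than the other.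

Compound 3 `O=c1[nH]nc2n(c1=O)CCN2c1ccc(Cl)cc1` has not been measured yet. Compared with compound 2, the change is chloro in place of methyl on an aromatic carbon. Within the data shown here, the one measured step, from compound 1 to compound 2, also touched that same aromatic carbon and moved the read-out by no more than the scatter. Among the measured compounds shown here, no measured pair speaks to chloro itself, so the expectation can only rest on that single step.

On this basis the step from compound 2 to compound 3 in this assay is expected to be a number 4 percentage points higher from compound 2 to compound 3 (within the scatter), nothing beyond the scatter. Compound 3 is therefore estimated to give 4%, with a likely range from 0% to 15%.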

Compound 3, a percentage reported as inhibition, at one concentration (the size of the read-out at that concentration, not a potency): 0%
Beside the measured number, compound 3's estimate is 4 percentage points above it, within the range that was stated.
By their numbers in this assay, from the lowest: compounds 2, 3 and 1 (each within the scatter of the next).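

In this assay, chloro in place of methyl on the aromatic carbon para to a large group gives no change at the digits printed from compound 2 to compound 3 (within the scatter) and so the two groups cannot be told apart at this position. Chloro in place of hydrogen on that same carbon gives a number 7 percentage points lower from compound 1 to compound 3 (within the scatter) and this shows that a chlorine, like the methyl carbon measured earlier, leaves the read-out of the unsubstituted compound 1 within the scatter; across these three compounds, hydrogen, methyl and chloro at this one position therefore give no step beyond the scatter. Nothing available here explains why these changes make so little difference.

From the compounds shown here alone, what stays open is whether a group of a different kind at this carbon, such as an amine, a carboxylic acid or a longer chain, would move the read-out beyond the scatter. Also open is whether a change elsewhere on the shared core would do so, and what any of these compounds would give at a concentration other than the one tested.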